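Swapping fluoro for cyano on the benzyl ring

The compounds below may be only part of what the source reports. "The series", "measured", "known", "first", "only" and "open" are said of these compounds alone.

an assay on isolated protein for inhibition of DNA nucleotidylexotransferase (Homo sapiens), read by scintillation counting, with a stated time of 10 min (a lower number here means a stronger inhibitor, a higher number a weaker inhibitor), has so far been run on two compounds that share one core. Compound 1 `O=C(/C=C/c1cc(C(=O)c2ccccc2)cn1Cc1ccccc1)CC(=O)C(=O)O` gives 16 uM, and compound 2 `O=C(/C=C/c1cc(C(=O)c2ccccc2)cn1Cc1ccc(F)cc1)CC(=O)C(=O)O` gives 9.5 uM. The only difference between them is fluoro in place of hydrogen on an aromatic carbon, and the step of a 1.7-fold lower number from compound 1 to compound 2 (0.23 log units; within the scatter), so the two numbers cannot be told apart; compound 2 merely shows the lower of the two.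

Compound 3 `N#Cc1ccc(Cn2cc(C(=O)c3ccccc3)cc2/C=C/C(=O)CC(=O)C(=O)O)cc1` keeps everything of compound 2 except that change: cyano in place of fluoro on an aromatic carbon. For the measured compounds named here, no measured step swaps fluoro for cyano, so the only guide is the step from compound 1 to compound 2 at the same aromatic carbon, which stayed within the scatter. The expectation for compound 3 is therefore a step of a 1.1-fold higher number from compound 2 to compound 3 (0.02 log units; within the scatter), with nothing beyond the scatter foreseen. In this assay compound 3 is expected at about 10 uM, estimated between 4 uM and 25 uM.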

Compound 3, concentration for 50% inhibition: 6.8 uM
Beside the measured number, compound 3's estimate is 1.5-fold (0.17 log units) above it; low and high end bracket the measured number.
By their numbers in this assay, from the lowest: compounds 3, 2 and 1 (each within the scatter of the next, the first and the last beyond it).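

In this assay, the exchange of fluoro for cyano gives a 1.4-fold lower number from compound 2 to compound 3 (0.15 log units; within the scatter), so at this aromatic carbon the two groups cannot be told apart. The comparison with the unsubstituted benzyl group is new: fluoro alone stayed within the scatter, whereas cyano gives a 2.4-fold lower number from compound 1 to compound 3 (0.37 log units; beyond the scatter), a modest step but the first in this set to pass beyond it. The position therefore accepts the 4-cyanobenzyl group, with its two heavy atoms and one hydrogen-bond acceptor in the entering group, and the number remains within the scatter of the 4-fluorobenzyl result.

Nothing available explains why compound 3 differs from compound 1. Going by these compounds, it also remains open whether an amine, a carboxylic acid or a longer chain at this aromatic carbon would move the number beyond the scatter of compound 3.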